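Replacing a Methyl Ester Arm with a Pyridine Ring

This account rests on a few compounds, and the source may have more. Where it says the series, first, only, none or still open, it means among the compounds named here.

Compound 1 `CC(O)c1cccc(C(=O)N[C@@H](C)Cn2ccc(-c3ccc(C#N)c(Cl)c3)n2)c1` gives 20100 nM in a functional assay on CWR22R cells (Homo sapiens) for antiproliferative activity, read by CCK-8 assay, with a stated time of 6 days (a higher number here means a weaker inhibitor, a lower number a stronger inhibitor), a weak result. Compound 2 `COC(=O)/C=C/C(=O)N[C@@H](C)Cn1ccc(-c2ccc(C#N)c(Cl)c2)n1` gives "not determined" (no result reported) in this assay, so it cannot be placed against compound 1. Compound 3 `C[C@@H](Cn1ccc(-c2ccc(C#N)c(Cl)c2)n1)Nc1ccncc1` differs from compound 2 in one place: pyridin-4-yl in place of (2-(methoxycarbonyl)ethenyl)carbonyl on an amine nitrogen. Compound 2 has no number. The size and direction of this step in this assay cannot be judged from the data; only a weakness comparable to compound 1 at 20100 nM seems a reasonable guide. For compound 3 an inhibitory concentration of about 12000 nM is expected, in the range 2500 nM to 50000 nM.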

Compound 3, half-maximal inhibitory concentration: 11500 nM
Compound 3: middle estimate off by 1.0-fold (0.02 log units), on the high side; measured number inside the range.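

Among these compounds, no step from compound 2 to compound 3 can be read in this assay, as compound 2 has no number there. On these data alone, whether pyridin-4-yl outperforms (2-(methoxycarbonyl)ethenyl)carbonyl on that amine nitrogen stays open. No evidence bears on these results.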